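Adding a Third Methoxy Group: From Compound 3 to Compound 4

The source may report more compounds than this note shows. Statements on the series, on what has been measured and on what is new or still open speak of the compounds shown alone.

Compound 1 `Cc1cc(O)c(C2=NN(c3ccc(S(N)(=O)=O)cc3)C(c3ccccc3Cl)C2)cc1Cl` — 20500 nM
Compound 2 `Cc1cc(O)c(C2=NN(c3ccc(S(N)(=O)=O)cc3)C(/C=C/c3ccccc3)C2)cc1Cl` — 42400 nM
Compound 3 `COc1ccc(C2CC(c3cc(Cl)c(C)cc3O)=NN2c2ccc(S(N)(=O)=O)cc2)cc1OC` — 24700 nM

Three compounds share a core and differ only in the aryl group on a saturated ring carbon. In a functional assay on A498 cells (Homo sapiens) for antiproliferative activity, with a stated time of 48 h (on this read-out higher numbers stand for weaker inhibition of growth and lower numbers for stronger inhibition of growth), compound 1 gives 20500 nM, compound 2 gives 42400 nM and compound 3 gives 24700 nM. Compound 3 stands second highest of the three numbers; its nearest neighbour is compound 1, separated by a 1.2-fold higher number from compound 1 to compound 3 (0.08 log units; within the scatter), which is within the scatter, and its furthest is compound 2, separated by a 1.7-fold lower number from compound 2 to compound 3 (0.23 log units; within the scatter), also within the scatter. Within the data shown here, the only step beyond the scatter is a 2.1-fold higher number from compound 1 to compound 2 (0.32 log units; beyond the scatter), a modest one.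

Compound 4 `COc1ccc(C2CC(c3cc(Cl)c(C)cc3O)=NN2c2ccc(S(N)(=O)=O)cc2)c(OC)c1OC` is not yet measured. It differs from compound 3 in one place: methoxy in place of hydrogen on an aromatic carbon. Among the measured compounds shown here, no measured step adds a methoxy group to this aryl ring, so the bearing of the three steps on it is only indirect: changes to the aryl group on this carbon have so far moved the numbers little, and the 3,4-dimethoxyphenyl of compound 3 sits among them without a clear difference from compound 1.

The author therefore expects for compound 4 a step of a 1.0-fold higher number from compound 3 to compound 4 (0.01 log units; within the scatter) in this assay, that is, no change beyond the scatter. For compound 4 the estimate is 25000 nM, with a range from 10000 nM to 60000 nM.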

Compound 4, concentration for total growth inhibition: 15300 nM
Beside the measured number, compound 4's estimate is 1.6-fold (0.21 log units) above it; the measured number falls inside the stated range.
By their numbers in this assay, from the lowest: compounds 4, 1, 3 and 2 (each within the scatter of the next, the first and the last beyond it).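

In this assay, methoxy in place of hydrogen on an aromatic carbon ortho to a large group and ortho to a methoxy group gives a 1.6-fold lower number from compound 3 to compound 4 (0.21 log units; within the scatter) and so leaves the 3,4-dimethoxyphenyl and 2,3,4-trimethoxyphenyl compounds not told apart on this read-out, which shows that this carbon of the aryl ring accepts the added methoxy without a change beyond the scatter. The 2,3,4-trimethoxyphenyl group also stays level with 2-chlorophenyl, with a 1.3-fold lower number from compound 1 to compound 4 (0.13 log units; within the scatter) as the step, whereas the change from 2-phenylethenyl gives a 2.8-fold lower number from compound 2 to compound 4 (0.44 log units; beyond the scatter) and is the widest step in the set, though still modest, so 2-phenylethenyl now stands apart from two of the three aryl groups while the 3,4-dimethoxyphenyl compound stays within the scatter of all the others. No measurement shown here offers an explanation for these numbers.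

The compounds shown leave open whether a group other than methoxy on this aromatic carbon, such as a hydroxyl, an amine or a carboxylic acid, would move the number beyond the scatter. They also leave open whether the added methoxy would behave the same way on an aryl ring without the other two methoxy groups.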